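Propyl for isopropyl on the shared core

This account rests on a few compounds, and the source may have more. Where it says the series, first, only, none or still open, it means among the compounds named here.

Three analogues on one core have been measured in an assay on isolated protein for inhibition of serine protease 1 (Bos taurus); on this read-out higher numbers stand for weaker inhibition and lower numbers for stronger inhibition. Compound 2 `CC(=N)N1CCC(Oc2ccc3nc(C(C)C)n(Cc4ccc5ccc(C(=N)N)cc5c4)c3c2)CC1` gives 5.7 nM in this assay, the lowest of the three numbers and beyond the scatter from both neighbours. Compound 1 `CCCCc1nc2cc(OC3CCN(C(C)=N)CC3)ccc2n1Cc1ccc2ccc(C(=N)N)cc2c1` gives 14 nM, and compound 3 `CC(=N)N1CCC(Oc2ccc3c(c2)nc(CCC(=O)O)n3Cc2ccc3ccc(C(=N)N)cc3c2)CC1` gives 14 nM. Within the data shown here, the only step recorded, no change at the digits printed from compound 1 to compound 3 (within the scatter), concerns a different position and does not bear directly on the question here. What does bear on it is the pair of values for compound 1 and compound 2, which differ only in the alkyl group at the same position and whose numbers lie apart beyond the scatter.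

Compound 4 `CCCc1nc2ccc(OC3CCN(C(C)=N)CC3)cc2n1Cc1ccc2ccc(C(=N)N)cc2c1` has not yet been measured. It differs from compound 2 by propyl in place of isopropyl on an aromatic carbon. Since the straight chain of compound 1 sits higher than the branched chain of compound 2, a modest rise in this assay is expected for compound 4, estimated as a 1.6-fold higher number from compound 2 to compound 4 (0.20 log units; within the scatter). The expected value for compound 4 is 9 nM, within a range from 4 nM to 20 nM.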

Compound 4, inhibition constant: 6.8 nM
Compound 4: middle estimate off by 1.3-fold (0.12 log units), on the high side; measured number inside the range.
By their numbers in this assay, from the lowest: compounds 2 and 4 (each within the scatter of the next); then compounds 1 and 3 (each within the scatter of the next).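

In this assay, moving the same three carbons from a branched to a straight arrangement on this aromatic carbon, which lies between two ring nitrogen atoms, gives a 1.2-fold higher number from compound 2 to compound 4 (0.08 log units; within the scatter). This is the first pair among the compounds shown that differs in this group alone, and it shows that the assay does not separate propyl from isopropyl at this place. The branching of this group therefore makes no difference that can be read here, though this rests on a single pair. Nothing measured alongside these numbers offers an explanation for this result.

The compounds shown leave open whether a shorter chain such as methyl, a longer chain such as pentyl, or a cyclopropyl ring would shift the number on this core. Going by these compounds, it is also open whether an amine or a carboxylic acid at the end of a propyl chain would do so.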